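The compounds below may be only part of what the source reports. "The series", "measured", "known", "first", "only" and "open" are said of these compounds alone.

Measured so far in a functional assay on Bel-7402 cells (Homo sapiens) for inhibition, read by MTT assay, with a stated time of 24 h, tested at 1 ug/mL; a higher number here means more inhibition of growth at the concentration tested, a lower number less inhibition of growth:

- Compound 1 (`O=C(CCCCC(S)CCS)NO`) gives 9.12%
- Compound 2 (`O=C(CCCCC1CCSS1)Nc1cccc2ccccc12`) gives 9.55%
- Compound 3 (`O=C(CCCCC(S)CCS)Nc1cccc(Cl)c1`) gives 1.14%

All three values lie within the usual scatter of one another, so compound 1 cannot be ranked apart from compound 2 or compound 3 on these numbers. Compound 4 (`O=C(CCCCC(S)CCS)Nc1ccccn1`) has not yet been measured. It differs from compound 1 by one change: pyridin-2-yl in place of hydroxy on an amide-type nitrogen, which puts pyridin-2-yl in place of hydroxy on an amide-type nitrogen.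

Going by the values given here, no measured pair shows this change on its own, so the evidence is indirect. Compound 3 at 1.14% and compound 2 at 9.55% also carry a ring on the amide-type nitrogen, and neither value stands clearly apart from that of compound 1. In this assay, no step beyond the scatter is therefore expected, in either direction. The estimated step, a number 3.1 percentage points lower from compound 1 to compound 4 (within the scatter), is expected to be small. For compound 4 the expected value is 6%, with an estimated range from 0% to 16%.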

Compound 4, percent growth inhibition at one concentration: "not active" (no number reported)
Compound 4 has no reported number here; there is nothing to compare the estimate with.
By their numbers in this assay, from the lowest: compounds 3, 1 and 2 (each within the scatter of the next).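

Going by these compounds alone, compound 4 is reported as not active in this assay, without a number, so no step from compound 1 to compound 4 can be read. No measurement shown here bears on this result. As far as these compounds go, what pyridin-2-yl in place of hydroxy does to growth inhibition remains open.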